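Swapping Fluorine for Methyl on a Cyclopropane Amide

This account rests on a few compounds, and the source may have more. Where it says the series, first, only, none or still open, it means among the compounds named here.

Three compounds share one core. Compound 1 `CC(=O)N1CC2CC(C1)N2` carries a plain acetyl group and in an assay on SH-EP1 cells for agonist activity at Neuronal acetylcholine receptor; alpha4/beta2 (Homo sapiens), read by FLIPR and calcium flux (a higher number here means that more compound is needed for the effect, a lower number that less compound is needed), compound 1 gives 5100 nM. Compound 2 `O=C([C@@H]1C[C@@H]1F)N1CC2CC(C1)N2` and compound 3 `O=C([C@H]1C[C@@H]1F)N1CC2CC(C1)N2` both replace that methyl with a 2-fluorocyclopropyl group and differ only in how one ring stereocentre is drawn, a point recorded as the fact that one of compounds 2 and 3 is drawn with a defined configuration and the other without, at the place where they differ. In this assay compound 2 gives 120 nM, and compound 3 gives 850 nM. The step of a 43-fold lower number from compound 1 to compound 2 (1.63 log units; beyond the scatter) is large, the step of a 6.0-fold lower number from compound 1 to compound 3 (0.78 log units; beyond the scatter) is modest, and the step of a 7.1-fold higher number from compound 2 to compound 3 (0.85 log units; beyond the scatter) is modest. Compound 3 therefore stands second highest of the three numbers, between the others.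

Compound 4 `C[C@H]1C[C@@H]1C(=O)N1CC2CC(C1)N2` is not yet measured. It differs from compound 3 by methyl in place of fluoro on a saturated ring carbon. Among the compounds with values here, no measured step exchanges fluoro for methyl on this ring; the measured steps only show that a substituted cyclopropyl carbonyl gives lower numbers than acetyl. The change is small in size, so the expectation is a step no larger than the scatter, in either direction: a 1.2-fold lower number from compound 3 to compound 4 (0.08 log units; within the scatter) is the estimated step. Compound 4 is expected to give about 700 nM in this assay, within a range from 150 nM to 3000 nM.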

Compound 4, half-maximal effective concentration: 9100 nM
Beside the measured number, compound 4's estimate is 13-fold (1.11 log units) below it; measured number outside the range, above it.
By their numbers in this assay, from the lowest: compound 2; then compound 3; then compounds 1 and 4 (each within the scatter of the next).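

In this assay, the group on this saturated ring carbon of the three-membered ring proves decisive: methyl in place of fluoro gives an 11-fold higher number from compound 3 to compound 4 (1.03 log units; beyond the scatter), and the comparison with the other fluoro compound gives a 76-fold higher number from compound 2 to compound 4 (1.88 log units; beyond the scatter). Against the plain acetyl group, the 2-methylcyclopropyl group brings no change that can be told from the scatter, with a 1.8-fold higher number from compound 1 to compound 4 (0.25 log units; within the scatter), so the lower numbers of compounds 2 and 3 cannot be credited to a substituted cyclopropyl carbonyl as such. Fluoro and methyl each count as one heavy atom, with no hydrogen-bond donors or acceptors and no net charge, so these counts alone do not separate two groups whose numbers lie far apart.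

The compounds shown leave open where an unsubstituted cyclopropyl group, or a chloro, hydroxy or trifluoromethyl group on the same ring carbon, would fall, and whether the other stereo forms of the 2-methylcyclopropyl compound would differ as compounds 2 and 3 do. Nothing measured here gives a reason for the difference between fluoro and methyl at this position.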